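The source may hold more compounds than are shown below. What is called first, only, known or untested is meant among the compounds shown, and "the series" means these compounds.

Measured set:
Compound 1, `CCc1nc(N)nc2c1c(-c1ccc3oc(N)nc3c1)nn2C(C)C`: in an ADME assay on microsomes from liver (Homo sapiens) for metabolic stability, read by LC-MS, with a stated time of 15 min, tested at 1 uM, in the presence of a further agent that is not named here (a lower number here means that less of the compound is left, a higher number that more of the compound is left), compound 1 gives 93%.
Compound 2, `CC(C)n1nc(-c2ccc3oc(N)nc3c2)c2c(CO)nc(N)nc21`: compound 2 gives > 95%, a limit of this assay.
Compound 3, `COc1nc(N)nc2c1c(-c1ccc3oc(N)nc3c1)nn2C(C)C`: compound 3 gives > 95%, also a limit of this assay.

Compound 1 is the only one of the three with a number rather than a limit; the two others sit at the limit of > 95% in this assay, at which 2 of the 3 values shown sit. Compound 4, `CC(C)n1nc(-c2ccc3oc(N)nc3c2)c2cnc(N)nc21`, differs from compound 1 by hydrogen in place of ethyl on an aromatic carbon. Both measured steps from compound 1 bear on this, since each alters the same ethyl group: a number at least 2 percentage points higher from compound 1 to compound 2 (that floor lies within the scatter) and a number at least 2 percentage points higher from compound 1 to compound 3 (that floor lies within the scatter). Neither moved beyond the scatter. No step beyond the scatter is therefore expected here, in either direction. Compound 4 is estimated at 92%, range 80% to 97%, meaning an expected a number 1 percentage points lower from compound 1 to compound 4 (within the scatter).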

Compound 4, percent of the compound remaining: 94%
Compound 4: middle estimate off by 2 percentage points, on the low side; low and high end bracket the measured number.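

Hydrogen on this aromatic carbon leaves no carbon substituent at the position, and this assay still gives a number 1 percentage points higher from compound 1 to compound 4 (within the scatter). The read-out therefore does not need the ethyl group here. The other two steps are a number at least 1 percentage points lower from compound 3 to compound 4 (that floor lies within the scatter) and a number at least 1 percentage points lower from compound 2 to compound 4 (that floor lies within the scatter), and both are bounded by the ceiling of the read-out: the limit of > 95% in this assay, at which 2 of the 4 values shown sit.

Going by these compounds, whether an amine, a carboxylic acid or a longer chain on this carbon would give a step beyond the scatter remains open. The compounds shown do not reveal any group at this position that lowers the amount of compound left.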